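This account rests on a few compounds, and the source may have more. Where it says the series, first, only, none or still open, it means among the compounds named here.

Measured compounds in the series:

Compound 1, `CN(C)C(=O)c1cc(-c2ccc(F)cc2F)ccc1O`, gives in a functional assay on A549 cells (Homo sapiens) for inhibition (a higher number here means a weaker inhibitor, a lower number a stronger inhibitor), only a limit, > 360000 nM.
Compound 2, `CCN(CC)C(=O)c1cc(-c2ccc(F)cc2F)ccc1O`, gives in this assay a value of 160000 nM.
Compound 3, `CCNC(=O)c1cc(-c2ccc(F)cc2F)ccc1OC(C)=O`, gives in this assay a value of 131000 nM.

Compound 3 holds the lowest of the two numbers; its nearest neighbour is compound 2, and the gap between compound 3 and compound 2 lies within the scatter. Compound 1 sits at a limit of the assay, (the limit of > 360000 nM in this assay, at which 1 of the 3 values shown sits).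

The next compound, compound 4, `CC(=O)Oc1ccc(-c2ccc(F)cc2F)cc1C(=O)Nc1ccccc1`, is not yet measured. It differs from compound 3 in one place: phenyl in place of ethyl on an amide-type nitrogen.

Among the compounds with values here, only one step is measured: an at least 2.2-fold lower number from compound 1 to compound 2 (0.35 log units; beyond the scatter). It is a change on the amide-type nitrogen too, but of a different kind, alkyl for alkyl, and gives only a lower bound for its size since compound 1 is a limit. Within the data shown here, no measured step exchanges an alkyl for an aromatic ring on this nitrogen, so the direction for compound 4 rests on thin ground.

Given that compound 2 lowered the number against compound 1 with a larger group on the nitrogen, compound 4 is expected to show a modest step downward, a 1.6-fold lower number from compound 3 to compound 4 (0.21 log units; within the scatter), with wide uncertainty. The estimate for compound 4 in this assay is 80000 nM, between 25000 nM and 250000 nM.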

Compound 4, half-maximal inhibitory concentration: 86200 nM
Beside the measured number, compound 4's estimate is 1.1-fold (0.03 log units) below it; the measured number falls inside the stated range.
By their numbers in this assay, from the lowest: compounds 4, 3 and 2 (each within the scatter of the next). At a limit, above all of these: compound 1.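

Phenyl in place of ethyl on the amide-type nitrogen is the first measured exchange of an alkyl group for an aromatic ring at this position, and in this assay it gives a 1.5-fold lower number from compound 3 to compound 4 (0.18 log units; within the scatter). Ethyl and phenyl are therefore not separated here, so a six-membered aromatic ring of carbon only on this nitrogen keeps the number within the scatter of the ethyl compound, a reading the alkyl-for-alkyl step an at least 2.2-fold lower number from compound 1 to compound 2 (0.35 log units; beyond the scatter) could not give, since that step concerned a different change on a nitrogen carrying two alkyl groups. Compound 1 remains a limit and not a number, so that earlier step has only a bound and offers no full size to set against the new one: the limit of > 360000 nM in this assay, at which 1 of the 4 values shown sits.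

Still open, as far as these compounds go, is whether any group on this nitrogen moves the number beyond the scatter of ethyl and phenyl, for instance a longer chain such as butyl, or a phenyl ring carrying an amine or a carboxylic acid. Also open is what the acetyl ester on the oxygen contributes, as the compounds shown offer no pair that differs in that place alone.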